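The source may report more compounds than this note shows. Statements on the series, on what has been measured and on what is new or still open speak of the compounds shown alone.

Compound 1 `COc1ccc2oc(/C=C/c3ccc(OC(F)(F)F)cc3)cc(=O)c2c1` in a functional assay on A549 cells (Homo sapiens) for antiproliferative activity, read by MTT assay, with a stated time of 12 h (a lower number here means a stronger inhibitor, a higher number a weaker inhibitor), gives > 40000 nM, a limit of the assay.
Compound 2 `COc1cc(OC)c2c(=O)cc(/C=C/c3ccc(OCC4CC4)cc3)oc2c1` gives 20900 nM.
Compound 3 `COc1ccc2c(=O)cc(/C=C/c3ccc(OC(F)(F)F)cc3)oc2c1` gives > 40000 nM, again a limit of the assay.

Within the data shown here, compound 2 stands as the only measured number among the three; the other two sit at the limit of > 40000 nM in this assay, at which 2 of the 3 values shown sit. Compound 4 `COc1cc(OC)c2c(=O)cc(/C=C/c3ccc(F)cc3)oc2c1` differs from compound 2 by fluoro in place of cyclopropylmethoxy on an aromatic carbon. Among the measured compounds shown here, no step between measured compounds is available to size this change, so its effect remains open. Compound 4 is expected to fall within the scatter of its parent or toward weaker inhibition, the step of a 1.4-fold higher number from compound 2 to compound 4 (0.16 log units; within the scatter) being the estimate. Compound 4 is estimated at 30000 nM in this assay, within a range from 10000 nM to 80000 nM, with a fair chance that only a limit is returned.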

Compound 4, half-maximal inhibitory concentration: 18600 nM
Estimate against measurement, compound 4: 1.6-fold (0.21 log units) above; low and high end bracket the measured number.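

In this assay, fluoro in place of cyclopropylmethoxy on this aromatic carbon gives a 1.1-fold lower number from compound 2 to compound 4 (0.05 log units; within the scatter), so this position loses the larger group and its three-membered ring with no change beyond the scatter. Compound 4, like compound 2, returns a number rather than a limit of the assay: the limit of > 40000 nM in this assay, at which 2 of the 4 values shown sit.

From the compounds shown here alone, whether any group at this position moves the number further remains open, for instance an amine, a carboxylic acid or a longer alkoxy chain. Also open, going by these compounds, is whether this change would behave the same way with a different substitution pattern on the shared core.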